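Swapping chloro for cyano on compound 1

The source may hold more compounds than are shown below. What is called first, only, known or untested is meant among the compounds shown, and "the series" means these compounds.

Compound 1 (`Cc1nsc(-c2ccc(N3CCN(c4cccc(Cl)c4)CC3)nn2)n1`) gives 0.6 nM in a functional assay (aorta) for inhibition, with Rattus norvegicus as the target, with a stated time of 8 days; on this read-out lower numbers stand for stronger inhibition and higher numbers for weaker inhibition
Compound 2 (`Cc1nsc(-c2ccnc(N3CCN(c4cccc(C(F)(F)F)c4)CC3)n2)n1`) gives > 100 nM, a limit of the assay
Compound 3 (`Nc1nsc(-c2ccc(N3CCN(c4cccc(C(F)(F)F)c4)CC3)nn2)n1`) gives 20 nM

Only two of these three results are actual numbers, because compound 2 reports just a limit. Compound 1 holds the lower of those two numbers, and the gap up to compound 3 lies beyond the usual scatter of repeated measurements. That makes compound 1 the natural reference point for the next compound.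

Compound 4 (`Cc1nsc(-c2ccc(N3CCN(c4cccc(C#N)c4)CC3)nn2)n1`) keeps the core of compound 1 and carries cyano in place of chloro on an aromatic carbon, meta to a large group (cyano in place of chloro on an aromatic carbon). The same difference can be read as 3-chlorophenyl to 3-cyanophenyl.

Within the data shown here, no two measured compounds differ in one place only, so no measured step shows how large this change should be. Compound 1 sits at 0.6 nM, the lowest number seen, so a single swap seems more likely to raise the number than to lower it. The estimated step is a modest rise, a 5.0-fold higher number from compound 1 to compound 4 (0.70 log units; beyond the scatter), meaning somewhat weaker inhibition is expected. Compound 4 is expected at 3 nM, with an estimated range of 0.7 nM to 15 nM in this assay.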

Compound 4, half-maximal inhibitory concentration: 3 nM
Estimate against measurement, compound 4: no gap at the digits printed; the measured number falls inside the stated range.
By their numbers in this assay, from the lowest: compound 1; then compound 4; then compound 3. At a limit, above all of these: compound 2.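

Among these compounds, the swap gives the first comparison here in which only one place changes: a 5.0-fold higher number from compound 1 to compound 4 (0.70 log units; beyond the scatter). It shows that this position on the aromatic ring responds to the choice of group, since 3-cyanophenyl gives weaker inhibition than 3-chlorophenyl, yet the change does not abolish inhibition: in this assay, compound 4 still gives 3 nM. Compound 2 carries a limit rather than a number, and neither compound in this step reaches that limit, so the size of the step can be read in full: the limit of > 100 nM in this assay, at which 1 of the 4 values shown sits.

One pair shows the size of this change but not its cause, and it cannot say whether cyano would have the same effect on a different core. From the compounds shown here alone, how a methoxy group, an amine or a carboxylic acid would fare at this position remains open, as does trifluoromethyl on the core of compound 1, which would connect compound 1 more directly with compound 3.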